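This account rests on a few compounds, and the source may have more. Where it says the series, first, only, none or still open, it means among the compounds named here.

Measured in a functional assay on the whole organism for antagonist activity, with Mus musculus as the target; a higher number here means that more compound is needed for the effect, a lower number that less compound is needed:
- compound 1 `CCC(=O)N(c1ccc(Cl)c(Cl)c1)C1CCCC1O` gives 9 mg/kg
- compound 2 `CCC(=O)N(c1cc(Cl)c(Cl)c(Cl)c1)C1CCCC1N(C)C` gives 40 mg/kg
- compound 3 `CCC(=O)N(c1ccc(Cl)c(Cl)c1)C1CCCC1N` gives 0.8 mg/kg

Compound 3 has the lowest number of the three. Compound 4 `CCNC1CCCC1N(C(=O)CC)c1ccc(Cl)c(Cl)c1` carries ethyl in place of hydrogen on an amine nitrogen. Within the data shown here, no measured step isolates this change. The closest is an 11-fold lower number from compound 1 to compound 3 (1.05 log units; beyond the scatter), a large step for amino in place of hydroxy, which shows that the number responds to a change at this ring carbon. Compound 2 is also substituted on that nitrogen, but it differs from compound 3 elsewhere too, so it gives no clean comparison. A moderate rise in this assay is therefore expected, smaller than the measured step. The expected step is a 3.8-fold higher number from compound 3 to compound 4 (0.57 log units; beyond the scatter) in size. Compound 4 is estimated at 3 mg/kg, with an expected range from 0.7 mg/kg to 13 mg/kg.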

Compound 4, dose for half-maximal effect: 2 mg/kg
Beside the measured number, compound 4's estimate is 1.5-fold (0.18 log units) above it; the range from low to high includes it.
By their numbers in this assay, from the lowest: compound 3; then compound 4; then compound 1; then compound 2.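

In this assay, the amine nitrogen on the saturated ring carbon tolerates ethyl in place of hydrogen at a modest cost, with a 2.5-fold higher number from compound 3 to compound 4 (0.40 log units; beyond the scatter). Substitution on this nitrogen does not erase the advantage over hydroxy, as the ethylamino group still gives a 4.5-fold lower number from compound 1 to compound 4 (0.65 log units; beyond the scatter). Nothing available explains either step.

On these data alone, whether a lone methyl or a longer chain such as butyl on this nitrogen would follow the same direction stays open. Compound 2, also substituted on that nitrogen, differs elsewhere too and cannot settle it.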